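Cinnamate Esters Against Pak Choi: Dropping One Chloro Group

A few compounds are considered here, and "the series" means these few. Any claim that something is new, unique, unknown or untested is made for them only; others in the source may bear on it.

Two esters of the same phenol share a cinnamate core and differ only in the aromatic ring of the acid part. Compound 1 `Cc1ccc(C(C)C)c(OC(=O)/C=C/c2ccc(C(C)C)cc2)c1` carries an isopropyl group on that ring and in a functional assay on the whole organism for inhibition, with Brassica rapa subsp. chinensis as the target, with a stated time of 3 days, tested at 100 ppm (a lower number here means less inhibition of growth, a higher number more inhibition of growth at the concentration tested), compound 1 gives 42%. Compound 2 `Cc1ccc(C(C)C)c(OC(=O)/C=C/c2ccc(Cl)cc2Cl)c1` carries two chloro groups instead, and in this assay compound 2 gives 33%. On the numbers shown, compound 2 sits at one end of the pair, with compound 1 as its only neighbour, and the gap between the two lies within the usual scatter, so the two cannot be told apart.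

Compound 3 `Cc1ccc(C(C)C)c(OC(=O)/C=C/c2ccc(Cl)cc2)c1` is not yet measured. Relative to compound 2 the change is hydrogen in place of chloro on an aromatic carbon. Within the data shown here, no step between measured compounds is available to calibrate such a change. Given how close compound 1 and compound 2 sit, the step from compound 2 to compound 3 is expected to be small, a number 4 percentage points higher from compound 2 to compound 3 (within the scatter), with no direction that stands out beyond the scatter. Compound 3 is therefore expected near 37%, in a range from 18% to 56%.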

Compound 3, percent growth inhibition at one concentration: 36%
For compound 3 the middle estimate is 1 percentage points above the measured one; the measured number falls inside the stated range.
By their numbers in this assay, from the lowest: compounds 2, 3 and 1 (each within the scatter of the next).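

Hydrogen in place of the chloro group ortho to a large group and meta to a chloro group gives, in this assay, a number 3 percentage points higher from compound 2 to compound 3 (within the scatter), the first single-place reading for this series: at this position, the read-out does not separate chloro from hydrogen. The other single-place change, chloro in place of isopropyl on an aromatic carbon, gives a number 6 percentage points lower from compound 1 to compound 3 (within the scatter), so that exchange also remains unresolved in this read-out. Nothing at hand bears on the reason for either result.

Still open, going by these compounds, is whether any substituent on this aromatic ring can move growth inhibition beyond the scatter, as hydrogen, chloro and isopropyl have not yet given a step that can be read as a difference at the one concentration tested. An amine, a carboxylic acid or a longer chain in place of the chloro or isopropyl group would test that question, and each single-place step would need to be read against the same scatter.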